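Anilide substituent series on the shared core: trifluoromethyl analogue

The source may report more compounds than this note shows. Statements on the series, on what has been measured and on what is new or still open speak of the compounds shown alone.

In an assay on isolated protein for inhibition of aldo-keto reductase family 1 member C4 (Homo sapiens), using NADPH (on this read-out lower numbers stand for stronger inhibition and higher numbers for weaker inhibition), compound 2 `N=c1oc2c(O)cccc2cc1C(=O)Nc1ccccc1Cl` gives > 10000 nM, which is a limit of the assay and not a number. Compound 1 `N=c1oc2c(O)cccc2cc1C(=O)Nc1cccc(F)c1` gives > 10000 nM in this assay, again a limit rather than a number. Compound 3 `N=c1oc2c(O)cccc2cc1C(=O)Nc1cccc(Cl)c1` likewise gives > 10000 nM, also a limit. All three values sit at the limit of > 10000 nM in this assay, at which 3 of the 3 values shown sit, so the steps a step that the two limits leave unreadable from compound 1 to compound 2, a step that the two limits leave unreadable from compound 1 to compound 3 and a step that the two limits leave unreadable from compound 2 to compound 3 cannot be sized from the measurements; none of them shows whether moving a halogen around the anilide ring, or exchanging fluoro for chloro, alters inhibition at all.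

Compound 4 `N=c1oc2c(O)cccc2cc1C(=O)Nc1ccccc1C(F)(F)F` differs from compound 2 by trifluoromethyl in place of chloro on an aromatic carbon. Within the data shown here, the steps that bear on this change are the three above, since each of them also varies only the substituent on the anilide ring, and each is unreadable. Among the measured compounds shown here, with no step resolved beyond the limit, there is no ground for expecting a step of any direction in this assay, and the likeliest outcome is a further limit. Compound 4 is therefore expected to give about 15000 nM, with a range from 5000 nM to 60000 nM. The estimated step that the limit leaves unreadable from compound 2 to compound 4 is expected to stay within the scatter.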

Compound 4, half-maximal inhibitory concentration: > 10000 nM
Compound 4: only a limit was reported; the forecaster's own chance of this, stated with the estimate: 75%; the middle value is on the limit's open side.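

In this assay compound 4 gives > 10000 nM as a limit of the assay and not a number, so the step between compound 2 and compound 4 cannot be read, and all values stay at one limit: the limit of > 10000 nM in this assay, at which 4 of the 4 values shown sit.

The compounds shown leave open whether any substituent on the anilide ring of the shared core gives measurable inhibition.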